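The compounds below may be only part of what the source reports. "The series", "measured", "known", "first", "only" and "open" are said of these compounds alone.

Measured compounds:
Compound 1, `COC(=O)[C@H](CC(C)C)NC(=O)c1ccc(/C=C2\SC(=O)N(CC(=O)NOCc3ccccc3)C2=O)cc1`: > 128000 nM
Compound 2, `COC(=O)[C@@H](NC(=O)c1ccc(/C=C2\SC(=O)N(CC(=O)NOCc3ccccc3)C2=O)cc1)C(C)C`: > 128000 nM
Compound 3, `CC(C)[C@H](NC(=O)[C@H](C)NC(=O)c1ccn(CC(=O)NOCc2ccccc2)c1)C(=O)O`: > 128000 nM

In a functional assay on MRC5 cells (Homo sapiens) for inhibition, read by microscopy and resazurin assay, with a stated time of 72 h (a lower number here means a stronger inhibitor, a higher number a weaker inhibitor), compound 1 gives > 128000 nM, which is a limit of the assay and not a number. In this assay compound 2 gives > 128000 nM, also only a limit. In this assay compound 3 gives > 128000 nM, again a limit. All three values sit at the limit of > 128000 nM in this assay, at which 3 of the 3 values shown sit.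

Compound 1 differs from compound 2 by isobutyl in place of isopropyl on a saturated chain carbon bound to an amide-type nitrogen and a carbonyl carbon. The step that the two limits leave unreadable from compound 2 to compound 1 cannot be read, since both ends are limits.

Compound 4, `CC(C)C[C@H](NC(=O)[C@H](C)NC(=O)c1ccn(CC(=O)NOCc2ccccc2)c1)C(=O)O`, is not yet measured. It differs from compound 3 by isobutyl in place of isopropyl on a saturated chain carbon bound to an amide-type nitrogen and a carbonyl carbon, the same change in the same place as that from compound 2 to compound 1. The difference between the core of compound 3 and the core of compound 2 is not broken down here.

Because compound 3 gives > 128000 nM, and because the comparable step that the two limits leave unreadable from compound 2 to compound 1 could not be read, compound 4 is expected to stay at the limit, an estimated step that the limit leaves unreadable from compound 3 to compound 4. Compound 4 is therefore estimated at 200000 nM, with an expected range from 100000 nM to 1000000 nM.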

Compound 4, half-maximal inhibitory concentration: > 128000 nM
Compound 4: no number, only a limit (the forecaster's own chance of this, stated with the estimate: 90%); the middle value does not contradict the limit.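

In this assay compound 4 gives > 128000 nM, which is a limit of the assay and not a number. Compound 3 also gives only a limit, so the step from isopropyl to isobutyl between compound 3 and compound 4 cannot be read. The compounds shown leave open what actual number any of them would give in this assay, and whether isobutyl in place of isopropyl makes any difference, with every value at one limit: the limit of > 128000 nM in this assay, at which 4 of the 4 values shown sit.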